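The source may report more compounds than this note shows. Statements on the series, on what has been measured and on what is new or still open speak of the compounds shown alone.

In a functional assay on UACC-62 cells (Homo sapiens) for cytotoxicity, read by sulforhodamine B assay (a lower number here means a stronger inhibitor of growth, a higher number a weaker inhibitor of growth), compound 1 `CC1=CC[C@@H]([C@@](C)(O)CCCC(C)(C)NC(=S)NN)CC1` gives only a limit, > 100000 nM, and not an exact number. Compound 2 `CC1=CC[C@@H]([C@@](C)(O)CCCC(C)(C)NC(=S)N/N=C\c2ccc(O)cc2)CC1` gives 40100 nM. Compound 3 `CC1=CC[C@@H]([C@@](C)(O)CCCC(C)(C)NC(=S)N/N=C\c2ccccc2[N+](=O)[O-])CC1` gives 16600 nM. Compound 2 therefore holds the higher of the two exact numbers, making it the weaker growth inhibitor of that pair.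

The next compound, compound 4 `CC1=CC[C@@H]([C@@](C)(O)CCCC(C)(C)NC(=S)N/N=C\c2ccc([N+](=O)[O-])cc2)CC1`, has not yet been measured. It changes compound 2 in one place, with nitro in place of hydroxy on an aromatic carbon, para to a large group: nitro in place of hydroxy on an aromatic carbon.

Two measured steps offer guidance. The first is an at least 2.4-fold lower number from compound 1 to compound 2 (0.39 log units; beyond the scatter), which added the aromatic group and says little about swapping a group on it. The closer guide is a 2.4-fold lower number from compound 2 to compound 3 (0.38 log units; beyond the scatter), where 2-nitrophenyl replaced 4-hydroxyphenyl, so a nitro group also entered there, though at a different place on the ring. A modest move towards a lower number is therefore expected, similar in size to that second step. The estimated change is a 2.1-fold lower number from compound 2 to compound 4 (0.32 log units; beyond the scatter). Compound 4 is expected to give about 19000 nM, within an estimated range of 7000 nM to 45000 nM.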

Compound 4, concentration for total growth inhibition: 62200 nM
Beside the measured number, compound 4's estimate is 3.3-fold (0.52 log units) below it, outside the stated range (above it).
By their numbers in this assay, from the lowest: compound 3; then compounds 2 and 4 (each within the scatter of the next). At a limit, above all of these: compound 1.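

In this assay, nitro in place of hydroxy on an aromatic carbon, para to a large group, gives a 1.6-fold higher number from compound 2 to compound 4 (0.19 log units; within the scatter), so at this position the two groups cannot be told apart. Where the nitro group sits does count in this small set: 4-nitrophenyl in place of 2-nitrophenyl gives a 3.7-fold higher number from compound 3 to compound 4 (0.57 log units; beyond the scatter), a separation the earlier step could not show, since it changed the group and its place together. Nothing measured here explains this difference between the two nitro compounds.

As far as these compounds go, whether an amine, a carboxylic acid or a methoxy group on that same aromatic carbon would stand apart from hydroxy and nitro remains open. So does whether a plain phenyl ring, carrying no such group at all, would fall near these values.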